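The source may hold more compounds than are shown below. What is called first, only, known or untested is meant among the compounds shown, and "the series" means these compounds.

Series notes. Of the compounds shown here, two have been measured in a functional assay on MKN-45 cells (Homo sapiens) for cytotoxicity, read by MTT assay, with a stated time of 72 h; a higher number here means a weaker inhibitor, a lower number a stronger inhibitor. Compound 1 `COc1cc2c(Oc3ccc(NC(=O)c4nn(-c5ccccc5)c(=O)c5ccccc45)cc3F)ccnc2cc1OCCCN1CCCCC1` gives 590 nM in this assay. Compound 2 `COc1cc2c(Oc3ccc(NC(=O)c4nn(-c5ccccc5F)c(=O)c5ccccc45)cc3F)ccnc2cc1OCCCN1CCCCC1` gives 350 nM in this assay. Among the measured compounds shown here, the only step between measured compounds, a 1.7-fold lower number from compound 1 to compound 2 (0.23 log units; within the scatter), is a fluoro in place of hydrogen on an aromatic carbon, and it stays within the scatter, so compound 2 stands level with compound 1 on the numbers so far.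

Compound 3 `COc1cc2c(Oc3ccc(NC(=O)c4nn(-c5ccc([N+](=O)[O-])cc5)c(=O)c5ccccc45)cc3F)ccnc2cc1OCCCN1CCCCC1` is the next member. It differs from compound 2 in one place: 4-nitrophenyl in place of 2-fluorophenyl on an aromatic nitrogen. For the measured compounds named here, no measured step bears directly on this change; the fluoro step from compound 1 to compound 2 touches the same phenyl ring but is a different substitution, and the numbers it produced did not move beyond the scatter. With nothing in the measured pair showing a clear response to substitution on this phenyl ring, the expected step of a 1.4-fold higher number from compound 2 to compound 3 (0.15 log units; within the scatter) is none beyond the scatter, with a wide range to allow for the larger change in substituent. The estimate for compound 3 in this assay is 500 nM, between 200 nM and 1500 nM.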

Compound 3, half-maximal inhibitory concentration: 1140 nM
Compound 3: the middle estimate sits 2.3-fold (0.36 log units) below what was measured; the range from low to high includes it.
By their numbers in this assay, from the lowest: compounds 2, 1 and 3 (each within the scatter of the next, the first and the last beyond it).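

In this assay, the substituent on the phenyl ring attached to the aromatic nitrogen now gives its first step beyond the scatter: 4-nitrophenyl in place of 2-fluorophenyl gives a 3.3-fold higher number from compound 2 to compound 3 (0.51 log units; beyond the scatter), a modest change. Set against the unsubstituted phenyl ring, nitro in place of hydrogen gives a 1.9-fold higher number from compound 1 to compound 3 (0.29 log units; within the scatter) and stays within the scatter, so compound 1 cannot be told apart from compound 2 or compound 3, and the only clear gap lies between the two substituted rings. No measured evidence bears on the reason for that gap.

Compound 2 and compound 3 differ both in the group and in where it sits on the ring, so the compounds shown leave open whether the gap follows the nitro group, the fluoro group or the place of substitution. From the compounds shown here alone, how an amine, a methoxy group or a carboxylic acid on this phenyl ring would read in this assay also stays open, as does whether any such group would move the number beyond the scatter from compound 1.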